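Replacing (1,3-dicarboxypropyl)amino with methoxycarbonyl

A few compounds are considered here, and "the series" means these few. Any claim that something is new, unique, unknown or untested is made for them only; others in the source may bear on it.

In a functional assay on CCRF-CEM cells (Homo sapiens) for cytotoxicity, in the absence of a further agent (a lower number here means a stronger inhibitor, a higher number a weaker inhibitor), compound 3 (`Nc1nc(N)c(CCCN(Cc2ccc(NC(CCC(=O)O)C(=O)O)cc2)c2cc(F)ccc2[N+](=O)[O-])c(O)n1`) gives > 100000 nM as its reading, which is a limit and not a number. Compound 4 (`COC(=O)c1ccc(CN(CCCc2c(N)nc(N)nc2O)c2cc(F)ccc2[N+](=O)[O-])cc1`) carries methoxycarbonyl in place of (1,3-dicarboxypropyl)amino on an aromatic carbon. Within the data shown here, no measured step covers this change, but two measured compounds also carry methoxycarbonyl. Compound 1 (`COC(=O)c1ccc(CN(CCCc2c(N)nc(N)nc2O)c2cc(F)cc(F)c2[N+](=O)[O-])cc1`) gives > 100000 nM as its reading, again a limit. Among the measured compounds shown here, compound 2 (`COC(=O)c1ccc(CN(CCCc2c(N)nc(N)nc2O)c2cc(F)c(F)cc2[N+](=O)[O-])cc1`) gives 59000 nM as the only true number here. Their fluorine patterns differ, and the one measured step is an at least 1.6-fold lower number from compound 1 to compound 2 (0.22 log units; that floor lies within the scatter) as shown. Much of this picture rests on the limit of > 100000 nM in this assay, at which 2 of the 3 values shown sit, alone. Only a modest move toward a lower number is therefore expected, estimated as an at least 1.4-fold lower number from compound 3 to compound 4 (0.15 log units; that floor lies within the scatter) overall. Compound 4 is expected at 70000 nM with an estimated range from 25000 nM to 130000 nM in this assay.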

Compound 4, half-maximal inhibitory concentration: 45000 nM
For compound 4 the middle estimate is 1.6-fold (0.19 log units) above the measured one; the range from low to high includes it.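

In this assay, methoxycarbonyl on this aromatic carbon gives a true number where (1,3-dicarboxypropyl)amino gave only a limit, with an at least 2.2-fold lower number from compound 3 to compound 4 (0.34 log units; beyond the scatter). Hydrogen in place of fluoro does not read the same in both cases, with a 1.3-fold lower number from compound 2 to compound 4 (0.12 log units; within the scatter), but an at least 2.2-fold lower number from compound 1 to compound 4 (0.34 log units; beyond the scatter). The effect of that swap therefore differs between compound 1 and compound 2.

Going by these compounds, the readings of compound 1 and compound 3 are limits, so the true size of the steps from them stays open: the limit of > 100000 nM in this assay, at which 2 of the 4 values shown sit. On these data alone, how a carboxylic acid or an amide on the same aromatic carbon would read also stays open.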